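A few compounds are considered here, and "the series" means these few. Any claim that something is new, unique, unknown or untested is made for them only; others in the source may bear on it.

For the measured compounds named here, compound 1 `CC(C)n1ncnc1-c1ccccc1NCC1=NCCN1` and compound 3 `CCCCn1ncnc1-c1ccccc1NCC1=NCCN1` carry a shared core, and in an in vitro functional assay on cells (Fibroblast) for agonist activity at Alpha-1D adrenergic receptor (Homo sapiens) (a higher number here means that more compound is needed for the effect, a lower number that less compound is needed), compound 1 gives 3160 nM while compound 3 gives 398 nM; the single measured step, a 7.9-fold lower number from compound 1 to compound 3 (0.90 log units; beyond the scatter), is the only direct evidence on how chain size on an aromatic nitrogen moves the read-out. Compound 2 `CCn1cc(-c2ccccc2NCC2=NCCN2)cn1` sits on a different core. In this assay compound 2 reaches only the limit of < 100000 nM, a limit of the assay rather than a number, as the limit of < 100000 nM in this assay, at which 1 of the 3 values shown sits, records. Compound 4 `Cn1cc(-c2ccccc2NCC2=NCCN2)cn1` differs from compound 2 by hydrogen in place of methyl on a saturated chain carbon bound to an aromatic nitrogen. With compound 2 at a limit, the step from compound 1 to compound 3 cannot be carried over numerically, and the removal of one carbon is expected to leave compound 4 at or near the same limit, so the expected step is a number no lower from compound 2 to compound 4 (the limit leaves the size open). In this assay compound 4 is estimated at 100000 nM, between 30000 nM and 300000 nM.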

Compound 4, half-maximal effective concentration: < 100000 nM
Compound 4: only a limit was reported (the forecaster's own chance of this, stated with the estimate: 80%); the middle value sits exactly at the limit.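

No step can be read from compound 2 to compound 4, since both values are limits and not numbers: the limit of < 100000 nM in this assay, at which 2 of the 4 values shown sit.
The compounds shown leave open whether ethyl to methyl on this core moves the read-out at all.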